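A few compounds are considered here, and "the series" means these few. Any claim that something is new, unique, unknown or untested is made for them only; others in the source may bear on it.

Among the measured compounds shown here, compound 1 `COc1cc2ncnc(Nc3ccc(NC(=O)c4ccc(C)cc4)cc3)c2cc1OC` stands at the top of the two numbers so far in a functional assay on MCF7 cells (Homo sapiens) for inhibition, read by MTT assay (a lower number here means a stronger inhibitor, a higher number a weaker inhibitor), where compound 1 gives 19000 nM. Its nearest neighbour, compound 2 `COc1cc2ncnc(Nc3ccc(NC(=O)c4cccc(F)c4)cc3)c2cc1OC`, gives 13600 nM in this assay, and the step of a 1.4-fold lower number from compound 1 to compound 2 (0.15 log units; within the scatter) stays inside the scatter. The unmeasured compound 3 `COc1cc2ncnc(Nc3ccc(NC(=O)c4cccc(Cl)c4)cc3)c2cc1OC` differs from compound 1 in one place: 3-chlorophenyl in place of 4-methylphenyl on a carbonyl carbon. For the measured compounds named here, the only measured step that bears on this change is the one from compound 1 to compound 2, which likewise replaces 4-methylphenyl with a 3-fluorophenyl on the carbonyl carbon and moved the number by a 1.4-fold lower number from compound 1 to compound 2 (0.15 log units; within the scatter), a shift within the scatter. Compound 3 is therefore expected to give a number close to that of compound 1, with the estimated step of a 1.5-fold lower number from compound 1 to compound 3 (0.16 log units; within the scatter) again small. The estimate for compound 3 in this assay is 13000 nM, within a range from 6000 nM to 30000 nM.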

Compound 3, half-maximal inhibitory concentration: 18000 nM
Compound 3: the middle estimate sits 1.4-fold (0.14 log units) below what was measured; measured number inside the range.
By their numbers in this assay, from the lowest: compounds 2, 3 and 1 (each within the scatter of the next).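

In this assay the 3-chlorophenyl group on this carbonyl carbon gives a 1.1-fold lower number from compound 1 to compound 3 (0.02 log units; within the scatter) against 4-methylphenyl, so compound 1 and compound 3 cannot be told apart at this position. The halogen exchange, chloro in place of fluoro on an aromatic carbon, gives a 1.3-fold higher number from compound 2 to compound 3 (0.12 log units; within the scatter) and so separates neither compound, which means that all three aryl groups seen here read alike in this assay. No measurement is at hand that would account for this flat result.

Whether any group on this carbonyl carbon can move the number beyond the scatter remains open, as all three compounds shown carry a substituted phenyl there. A carboxylic acid or an amine on that phenyl ring, or a cyclohexyl group in its place, would put this to the test.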